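The compounds below may be only part of what the source reports. "The series", "measured", "known", "first", "only" and "open" are said of these compounds alone.

Compound 1 `COc1cc(C=Cc2ccc3ccccc3c2)c(C(=O)O)c(OC)c1` and compound 2 `COc1cc(Cl)cc(C=Cc2ccc3ccccc3c2)c1C(=O)O` share one core, compound 2 carrying a chloro where compound 1 carries a methoxy. In an ADME assay on HepG2 cells (Homo sapiens) for cytotoxicity, read by resazurin assay, with a stated time of 24 h (on this read-out higher numbers stand for lower toxicity in this test and lower numbers for higher toxicity in this test), compound 1 reaches only a limit, > 100000 nM. In this assay compound 2 gives 104000 nM, the only true number shown, and it sits close to the limit of > 100000 nM in this assay, at which 1 of the 2 values shown sits. The step that the limit leaves unreadable from compound 1 to compound 2 therefore cannot be sized. Compound 3 `COc1cccc(C=Cc2ccc3ccccc3c2)c1C(=O)O` differs from compound 2 by hydrogen in place of chloro on an aromatic carbon. No readable step bears on this change, so no shift beyond the scatter is expected. Compound 3 is estimated at 100000 nM, within 50000 nM to 200000 nM, an expected step of a 1.0-fold lower number from compound 2 to compound 3 (0.02 log units; within the scatter).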

Compound 3, half-maximal cytotoxic concentration: > 100000 nM
Compound 3: a limit, no number; the forecaster's own chance of this, stated with the estimate: 50%; the middle value sits exactly at the limit.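

In this assay, going by these compounds alone, compound 3 gives > 100000 nM, a limit and not a number, so no step among compound 1, compound 2 and compound 3 can be read. From the compounds shown here alone, whether hydrogen, chloro or methoxy on that aromatic carbon changes the read-out stays open.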